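Trimming the Biaryl: Hydroxymethyl in Place of Ethylphenyl

The source may hold more compounds than are shown below. What is called first, only, known or untested is meant among the compounds shown, and "the series" means these compounds.

Compound 1 `CCc1ccc(-c2ccc(NC3=CC(=O)c4ncncc4C3=O)cc2)cc1`: 2000 nM
Compound 2 `CC(=O)c1cccc(NC2=CC(=O)c3ncncc3C2=O)c1`: 2300 nM
Compound 3 `O=C1C(NCc2ccc(F)cc2)=CC(=O)c2ncncc21`: 1700 nM

In a functional assay on MIA PaCa-2 cells (Homo sapiens) for cytotoxicity, read by MTT assay, with a stated time of 72 h (a higher number here means a weaker inhibitor, a lower number a stronger inhibitor), compound 1 gives 2000 nM, the second highest of the three numbers; compound 2 sits slightly above and compound 3 slightly below, both within the usual scatter, so the three compounds stand together. Compound 4 `O=C1C(Nc2ccc(CO)cc2)=CC(=O)c2ncncc21` differs from compound 1 by hydroxymethyl in place of 4-ethylphenyl on an aromatic carbon. Among the compounds with values here, no measured pair shows a change of this kind, so the size of the step is uncertain. With a large group leaving and a small one entering, the step of a 1.5-fold higher number from compound 1 to compound 4 (0.18 log units; within the scatter) is expected to be modest, toward a higher number, and may not exceed the scatter. Compound 4 is estimated at 3000 nM, with a range from 1000 nM to 9000 nM.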

Compound 4, half-maximal inhibitory concentration: 3500 nM
Compound 4: the middle estimate sits 1.2-fold (0.07 log units) below what was measured; the range from low to high includes it.
By their numbers in this assay, from the lowest: compounds 3, 1, 2 and 4 (each within the scatter of the next, the first and the last beyond it).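

In this assay, within the data shown here, hydroxymethyl in place of 4-ethylphenyl gives a 1.8-fold higher number from compound 1 to compound 4 (0.24 log units; within the scatter) and shows for the first time that this aromatic carbon can lose a whole six-membered aromatic ring without a step beyond the scatter. The large group therefore makes no measurable difference to the number in this single pair. Nothing at hand explains this result.

On these data alone, whether an amine, a carboxylic acid or a longer chain on the same carbon would also stay within the scatter remains open. So does whether a methyl group there would behave like hydroxymethyl.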